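A Methoxycarbonyl Ester Added to a Weak Benzyloxy Analogue

A few compounds are considered here, and "the series" means these few. Any claim that something is new, unique, unknown or untested is made for them only; others in the source may bear on it.

Compound 1 `COc1ccc(C(OCc2ccccc2)c2cccc3ccccc23)c(OC)c1OC` gives > 20000 nM in a functional assay on MDA-MB-231 cells (Homo sapiens) for inhibition, read by sulforhodamine B assay, with a stated time of 48 h (on this read-out higher numbers stand for weaker inhibition and lower numbers for stronger inhibition), a limit of the assay.
Compound 2 `COc1ccc(C(c2ccc(OCCO)cc2)c2cccc3ccccc23)c(OC)c1OC` gives > 20000 nM, also a limit.
Compound 3 `COc1ccc(C(c2ccc(O)cc2)c2cccc3ccccc23)c(OC)c1OC` gives 17400 nM.

Compound 1 stands only at a limit, not at a number. (the limit of > 20000 nM in this assay, at which 2 of the 3 values shown sit). The measured steps a step that the two limits leave unreadable from compound 1 to compound 2 and an at least 1.1-fold lower number from compound 1 to compound 3 (0.06 log units; that floor lies within the scatter) replace the whole benzyloxy group, so neither bears on the change to compound 4 `COC(=O)c1ccc(COC(c2ccc(OC)c(OC)c2OC)c2cccc3ccccc23)cc1`, which keeps benzyloxy and adds (methoxycarbonyl in place of hydrogen on an aromatic carbon). For the measured compounds named here, with no measured step to read this change from, no shift beyond the scatter is expected in this assay. Compound 4 is therefore expected to show a step that the limit leaves unreadable from compound 1 to compound 4. The estimated value of compound 4 is 25000 nM, within a range from 8000 nM to 60000 nM, most likely again only a limit.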

Compound 4, half-maximal inhibitory concentration: > 20000 nM
Compound 4: no number, only a limit (the forecaster's own chance of this, stated with the estimate: 70%); the middle value does not contradict the limit.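

Compound 1 and compound 4 both stop at a limit in this assay rather than at a number, so no step between them can be read: the limit of > 20000 nM in this assay, at which 3 of the 4 values shown sit.

Whether methoxycarbonyl in place of hydrogen changes the inhibition at all stays open among the compounds shown.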